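A Cyclohexyl in Place of 1-Phenylethyl: Compound 3 to Compound 4

The source may report more compounds than this note shows. Statements on the series, on what has been measured and on what is new or still open speak of the compounds shown alone.

In an ADME assay on cells (Hepatocyte, Homo sapiens) for pharmacokinetics, read by LC-MS, with a stated time of 90 min, tested at 1 uM (on this read-out lower numbers stand for slow clearance and higher numbers for fast clearance), compound 3 `C[C@H](Nc1c(NCCCCCC(=O)NO)c(=O)c1=O)c1ccccc1` is known only through a limit of the assay, giving < 5 uL/min. Compound 1 `O=C(CCCCCNc1c(Nc2ccccc2)c(=O)c1=O)NO` likewise gives a limit, < 4.8 uL/min. Compound 2 `O=C(CCCCCNc1c(NCc2ccccc2)c(=O)c1=O)NO` also gives a limit, < 4.8 uL/min. The steps a step that the two limits leave unreadable from compound 1 to compound 2, a step that the two limits leave unreadable from compound 1 to compound 3 and a step that the two limits leave unreadable from compound 2 to compound 3 therefore cannot be sized. Compound 4 `O=C(CCCCCNc1c(NC2CCCCC2)c(=O)c1=O)NO` differs from compound 3 by cyclohexyl in place of 1-phenylethyl on a nitrogen on an aromatic ring. Going by the values given here, no measured step replaces the group on this nitrogen with a non-aromatic ring, so none bears directly on the change; all three measured compounds sit at the limit of < 4.8 uL/min in this assay, at which 2 of the 3 values shown sit, or (the limit of < 5 uL/min in this assay, at which 1 of the 3 values shown sits). In this assay compound 4 is expected to stay at the low end as well, an estimated 3.5 uL/min with a range from 1.5 uL/min to 9 uL/min, which means an expected step that the limit leaves unreadable from compound 3 to compound 4.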

Compound 4, intrinsic clearance in a liver preparation (reported as CLH), per the amount of preparation that the assay uses: < 5 uL/min
Compound 4 ended at the assay's limit; the forecaster's own chance of this, stated with the estimate: 75%; the middle value lies beyond the limit too.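

In this assay compound 4 gives < 5 uL/min, which is a limit. Going by these compounds alone, compound 1, compound 2 and compound 3 also give only limits, so no step to compound 4 can be read. As far as these compounds go, the true clearance of all four compounds, and whether the group on the nitrogen alters it, stays open.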